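The compounds below may be only part of what the source reports. "The series", "measured", "known", "first", "only" and "open" are said of these compounds alone.

The series rests on one shared core, present in compound 1 `O=C(c1ccco1)[C@H]1C[C@@H]2CNC[C@@H](C2)C1` and in compound 2 `CNC(=O)[C@H]1C[C@@H]2CNC[C@@H](C2)C1`. For compound 1, the entry in an assay on SHEP1 cells for agonist activity at Neuronal acetylcholine receptor; alpha4/beta2 (Homo sapiens), read by FLIPR and calcium flux (on this read-out higher numbers stand for an effect only at larger amounts of compound and lower numbers for an effect already at smaller amounts), reads "not determined" (no result reported), so nothing can be said about it beyond its structure. In this assay, going by the values given here, compound 2 gives 2000 nM, and this is the only number available for the whole set, the other entry being compound 1 without a figure.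

Compound 3 `CC(C)NC(=O)[C@H]1C[C@@H]2CNC[C@@H](C2)C1` has not been measured. It differs from compound 2 in a single place: isopropyl in place of methyl on an amide-type nitrogen. The change sits on an amide-type nitrogen whose other neighbour is the carbonyl carbon, so the core itself is untouched.

Among the compounds with values here, no measured pair in this set covers a comparable exchange, so there is no step to lean on. The expectation for compound 3 in this assay is therefore a step of modest size, a 1.5-fold higher number from compound 2 to compound 3 (0.18 log units; within the scatter), leaning toward a weaker effect rather than a stronger one, but possibly no larger than the scatter. On that basis compound 3 is estimated at 3000 nM, within a range from 800 nM to 12000 nM.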

Compound 3, half-maximal effective concentration: 1900 nM
Compound 3: the middle estimate sits 1.6-fold (0.20 log units) above what was measured; measured number inside the range.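

In this assay, exchanging methyl for isopropyl on the amide-type nitrogen gives a 1.1-fold lower number from compound 2 to compound 3 (0.02 log units; within the scatter) and so leaves the two compounds indistinguishable on this read-out. Going by these compounds alone, this is the first reading of any change at this position, and it shows that going from 1 heavy atom to 3 on that nitrogen does not move the number beyond the scatter, a statement that rests on this single pair alone. Nothing available explains this result or bears on it.

The compounds shown leave open whether the number would also hold with a longer chain such as n-butyl, a cyclic group such as cyclohexyl or benzyl, or a chain ending in an amine or a carboxylic acid on the same nitrogen. They also leave open what happens with the amide hydrogen alone in place of an alkyl group, and so whether this position responds to any exchange at all or only stays level across the methyl and isopropyl pair.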